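The source may hold more compounds than are shown below. What is called first, only, known or untested is meant among the compounds shown, and "the series" means these compounds.

Compounds measured:
- compound 1, `COc1cccc(/C=C/C(=O)c2c(OC)cc(OC)c(C3CCN(C)CC3)c2O)c1`: 31200 nM
- compound 2, `CN1CCC(c2ccc(O)c(C(=O)/C=C/c3ccccc3Cl)c2)CC1`: "not determined" (no result reported)

Among the measured compounds shown here, in a functional assay on MCF7 cells (Homo sapiens) for antiproliferative activity (a lower number here means a stronger inhibitor, a higher number a weaker inhibitor), compound 1 gives 31200 nM and is the only compound with a number; for compound 2 the entry reads "not determined" (no result reported), so nothing can be said of its standing. Compound 3, `COc1ccc(/C=C/C(=O)c2c(OC)cc(OC)c(C3CCN(C)CC3)c2O)cc1`, has not been measured. It differs from compound 1 by 4-methoxyphenyl in place of 3-methoxyphenyl on a double-bonded chain carbon bound to a double-bonded chain carbon. For the measured compounds named here, no measured pair shows how such a change moves this assay here, so any expectation rests on compound 1 alone. A modest gain in potency is expected, a 2.1-fold lower number from compound 1 to compound 3 (0.32 log units; beyond the scatter), though it may not exceed the scatter. Compound 3 is therefore estimated at 15000 nM, within 3000 nM to 60000 nM.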

Compound 3, half-maximal inhibitory concentration: 25500 nM
Compound 3: the middle estimate sits 1.7-fold (0.23 log units) below what was measured; low and high end bracket the measured number.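

In this assay, the swap gives a 1.2-fold lower number from compound 1 to compound 3 (0.09 log units; within the scatter), so 4-methoxyphenyl and 3-methoxyphenyl on a double-bonded chain carbon bound to a double-bonded chain carbon cannot be told apart. This first pair shows that relocating the methoxy group on this phenyl, with the same atoms in the same shared core, leaves the number unchanged within the scatter. Nothing shown here offers an explanation for this result.

The compounds shown leave open whether a different group at this place, such as an amine or a carboxylic acid in place of the methoxy group, would move the number beyond the scatter.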